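The source may report more compounds than this note shows. Statements on the series, on what has been measured and on what is new or still open speak of the compounds shown alone.

In a functional assay on HeLa cells (Homo sapiens) for antiproliferative activity, read by MTT assay, with a stated time of 72 h (on this read-out higher numbers stand for weaker inhibition and lower numbers for stronger inhibition), compound 1 `O=c1cc(CSC(=S)N2CCCC2)oc2ccccc12` gives 23100 nM. Compound 2 `O=c1cc(CSC(=S)N2CCCC2)oc2cc(Cl)ccc12` gives only a limit of the assay, > 40000 nM. The step of an at least 1.7-fold higher number from compound 1 to compound 2 (0.23 log units; that floor lies within the scatter) rests on that limit (the limit of > 40000 nM in this assay, at which 1 of the 2 values shown sits), so compound 2 stands at the weak end of the numbers shown, without a value of its own. Compound 3 `O=c1cc(CSC(=S)N2CCOCC2)oc2cc(Cl)ccc12` differs from compound 2 by morpholin-4-yl in place of pyrrolidin-1-yl on a thiocarbonyl carbon. No measured step touches the thiocarbonyl side of the molecule, and nothing shown sets a direction; the expected step that the limit leaves unreadable from compound 2 to compound 3 is none beyond the scatter. Compound 3 is therefore estimated at 50000 nM, within 20000 nM to 150000 nM.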

Compound 3, half-maximal inhibitory concentration: 33300 nM
Beside the measured number, compound 3's estimate is 1.5-fold (0.18 log units) above it; measured number inside the range.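

In this assay, the change to morpholin-4-yl on a thiocarbonyl carbon gives the only step shown on this side of the molecule: an at least 1.2-fold lower number from compound 2 to compound 3 (0.07 log units; that floor lies within the scatter). Among the compounds shown here, compound 3 has a measured number, and with it the chloro series gains its only exact value. Compound 2 has only a limit of the assay, so the true size of this step stays unknown: the limit of > 40000 nM in this assay, at which 1 of the 3 values shown sits.

The compounds shown leave open how morpholin-4-yl behaves on the unchlorinated core of compound 1. They also leave open whether piperidin-1-yl or an open-chain diethylamino group at this carbon would give a different number.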